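The source may report more compounds than this note shows. Statements on the series, on what has been measured and on what is new or still open speak of the compounds shown alone.

Of the compounds shown here, three have been tested in an assay on isolated protein for inhibition of Rho-associated protein kinase 1 (Homo sapiens), tested at 30 uM; a lower number here means less inhibition, a higher number more inhibition at the concentration tested (going by the name of the read-out). Compound 1 `Cn1cnc2c(Nc3ccc(F)cc3)ncnc21` gives 7%, and compound 2 `Cn1cnc2c(Sc3ccc(F)cc3)ncnc21` gives 6%; these two numbers lie within the usual scatter of each other, so nothing separates them. Compound 3 `c1ccc(CSc2ncnc3[nH]cnc23)cc1` gives 28%, the highest of the three numbers. Its nearest neighbour is compound 1, whose number is lower by a gap beyond the scatter, and compound 2 stands furthest from it, lower by a gap that is also beyond the scatter. Each of these compounds differs from the others in more than one place, so no single change can be tied to any of these gaps.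

Compound 4 `Cn1cnc2c(SCc3ccccc3)ncnc21` has not yet been measured. It differs from compound 3 in one place only: methyl in place of hydrogen on an aromatic nitrogen. Because compound 3 gives 28% and nothing measured shows the effect of this change on its own, the expectation rests on compound 3 alone, and a small downward step is expected, about the size of the scatter or a little beyond it, as a number 10 percentage points lower from compound 3 to compound 4 (within the scatter). For compound 4 the estimated inhibition is 18%, expected to lie between 5% and 35%.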

Compound 4, a percentage reported as inhibition, at one concentration (the size of the read-out at that concentration, not a potency): 1%
Compound 4: middle estimate off by 17 percentage points, on the high side, and the stated range ends above it.
By their numbers in this assay, from the lowest: compounds 4, 2 and 1 (each within the scatter of the next); then compound 3.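

Going by these compounds alone, this is the first pair in the set that differs in one place only, so a gap can now be tied to a single change: in this assay, methyl in place of hydrogen on an aromatic nitrogen of the five-membered ring gives a number 27 percentage points lower from compound 3 to compound 4 (beyond the scatter). The position is therefore not a neutral one for this read-out, since this one added carbon, with the rest of the structure unchanged, takes compound 4 down to 1%. Within the data shown here, nothing measured so far says why the number falls with this change.

The compounds shown do not tell whether the same drop would follow from ethyl, a longer chain or a chain ending in an amine on this nitrogen, which would show whether any group at this place lowers the number or methyl does so in particular. They also leave open whether hydrogen in place of methyl on this nitrogen would raise the numbers of compound 1 and compound 2, so this step is so far known only for the side chain that compound 3 and compound 4 share.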